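This account rests on a few compounds, and the source may have more. Where it says the series, first, only, none or still open, it means among the compounds named here.

Compound 1 `CC1(C)CC(NC(=S)Nc2ccc(C#N)cc2)c2cc(Cl)ccc2O1`: 10000 nM
Compound 2 `CC1(C)CC(NC(=S)Nc2cccc([N+](=O)[O-])c2)c2cc(Br)ccc2O1`: 4000 nM
Compound 3 `CC1(C)CC(NC(=S)Nc2cccc(Cl)c2)c2cc(Br)ccc2O1`: 8000 nM

In a functional assay on U-373MG ATCC cells (Homo sapiens) for inhibition, read by MTT assay, with a stated time of 72 h (on this read-out lower numbers stand for stronger inhibition and higher numbers for weaker inhibition), compound 3 gives 8000 nM, which lies within the scatter of both other values. Compound 4 `CC1(C)CC(NC(=S)Nc2ccc(C#N)cc2)c2cc(Br)ccc2O1` has not yet been measured. Its difference from compound 3 is 4-cyanophenyl in place of 3-chlorophenyl on an amide-type nitrogen. Among the compounds with values here, the one measured step that bears directly on this part of the structure is a 2.0-fold higher number from compound 2 to compound 3 (0.30 log units; within the scatter), and it stays within the scatter. Compound 1 already carries 4-cyanophenyl, on a slightly different core, and gives 10000 nM. No change beyond the scatter is therefore expected in this assay. The expected step is a 1.1-fold higher number from compound 3 to compound 4 (0.05 log units; within the scatter). For compound 4 the estimated value is 9000 nM, with an expected range of 4000 nM to 20000 nM.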

Compound 4, half-maximal inhibitory concentration: 22000 nM
Estimate against measurement, compound 4: 2.4-fold (0.39 log units) below; measured number outside the range, above it.
By their numbers in this assay, from the lowest: compounds 2, 3 and 1 (each within the scatter of the next, the first and the last beyond it); then compound 4.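

In this assay, within the data shown here, 4-cyanophenyl in place of 3-chlorophenyl on the amide-type nitrogen gives a 2.8-fold higher number from compound 3 to compound 4 (0.44 log units; beyond the scatter) and is the first step at this position to lie beyond the scatter. With 4-cyanophenyl held constant, bromo in place of chloro on an aromatic carbon gives a 2.2-fold higher number from compound 1 to compound 4 (0.34 log units; beyond the scatter) and shows that this second place also shifts the number. No measured evidence bears on the cause of either step. The compounds shown leave open how a phenyl group carrying an amine or a carboxylic acid would read on that nitrogen. They also leave open whether the bromo-for-chloro step would hold with 3-chlorophenyl in place.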